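Working notes: from compound 3 to compound 4

The source may hold more compounds than are shown below. What is called first, only, known or untested is meant among the compounds shown, and "the series" means these compounds.

- compound 1 `CCCc1ccc(NC2=CC(=O)c3nc4n(c3C2=O)[C@H]2OC[C@@H](O)[C@H]2OC4)cc1`: 4990 nM
- compound 2 `O=C1C=C(NC2CCCCC2)C(=O)c2c1nc1n2[C@H]2OC[C@@H](O)[C@H]2OC1`: > 16000 nM (a limit)
- compound 3 `O=C1C=C(Nc2cccc(F)c2)C(=O)c2c1nc1n2[C@H]2OC[C@@H](O)[C@H]2OC1`: 6440 nM
- compound 4 `O=C1C=C(Nc2ccc(Br)cc2)C(=O)c2c1nc1n2[C@H]2OC[C@@H](O)[C@H]2OC1`: not yet measured

In a functional assay on HeLa cells (Homo sapiens) for inhibition, read by sulforhodamine B assay (on this read-out lower numbers stand for stronger inhibition and higher numbers for weaker inhibition), compound 3 gives 6440 nM, which is within the scatter of compound 1, as a 1.3-fold higher number from compound 1 to compound 3 (0.11 log units; within the scatter) shows. The value of compound 2 is a limit. Compound 4 has 4-bromophenyl in place of 3-fluorophenyl on an amine nitrogen.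

Among the compounds with values here, two measured steps bear on this change. Exchanging one phenyl group for another, a 1.3-fold higher number from compound 1 to compound 3 (0.11 log units; within the scatter), stayed within the scatter, whereas the step with cyclohexyl, an at least 2.4-fold lower number from compound 2 to compound 3 (0.39 log units; beyond the scatter), went beyond it. Compound 4 keeps a phenyl group, so no step beyond the scatter is expected in this assay. The expected step is a 1.3-fold lower number from compound 3 to compound 4 (0.11 log units; within the scatter). For compound 4 the estimate is 5000 nM, with an expected range of 2000 nM to 12000 nM.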

Compound 4, half-maximal inhibitory concentration: 3830 nM
The estimate for compound 4 lay 1.3-fold (0.12 log units) above the measured number; measured number inside the range.
By their numbers in this assay, from the lowest: compounds 4, 1 and 3 (each within the scatter of the next). At a limit, above all of these: compound 2.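

In this assay, a third phenyl-type group on this amine nitrogen again stays within the scatter of the other two: a 1.7-fold lower number from compound 3 to compound 4 (0.23 log units; within the scatter) and a 1.3-fold lower number from compound 1 to compound 4 (0.11 log units; within the scatter). The separation of cyclohexyl from the phenyl-type groups now holds for 4-bromophenyl as well: an at least 4.1-fold lower number from compound 2 to compound 4 (0.62 log units; beyond the scatter). The value of compound 2 is a limit: the limit of > 16000 nM in this assay, at which 1 of the 4 values shown sits.

On these data alone, what a phenyl group carrying an amine or a carboxylic acid would give remains open. Since 3-fluorophenyl and 4-bromophenyl differ in both substituent and its place, these two effects also remain unseparated.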